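Trading a benzoyl for hydrogen in compound 1

The source may report more compounds than this note shows. Statements on the series, on what has been measured and on what is new or still open speak of the compounds shown alone.

Among the compounds with values here, in a functional assay on RPMI-8226 cells (Homo sapiens) for cytotoxicity, read by MTT assay, with a stated time of 48 h (a higher number here means a weaker inhibitor, a lower number a stronger inhibitor), compound 1 `O=C(c1ccccc1)N(N=C1C(Cl)=C(Cl)C(Cl)=C1Cl)C(=O)c1ccccc1` gives 800 nM, the only actual number available so far. Compound 2 `ClC1=C(Cl)C(Cl)=C(Cl)C1=NNC1CCCCC1`, which carries no benzoyl, is reported only as a limit, > 3000 nM. The next compound is compound 3 `O=C(NN=C1C(Cl)=C(Cl)C(Cl)=C1Cl)c1ccccc1`, which has not yet been measured. It departs from compound 1 in one place: hydrogen in place of benzoyl on an amide-type nitrogen. In words, hydrogen stands in place of benzoyl on an amide-type nitrogen.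

Within the data shown here, no measured pair of compounds differs in a single place, so no direct step shows what this change is worth in this assay. The limit of compound 2, > 3000 nM, is the only hint of a direction, and it is a weak one. A moderate weakening is therefore expected, though a result within the usual scatter would not be surprising. The estimated change is a 1.9-fold higher number from compound 1 to compound 3 (0.27 log units; within the scatter), a modest rise in the read-out. For compound 3 the expected value is 1500 nM, with an estimated range from 500 nM to 4500 nM.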

Compound 3, half-maximal inhibitory concentration: 600 nM
The estimate for compound 3 lay 2.5-fold (0.40 log units) above the measured number; low and high end bracket the measured number.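

In this assay, within the data shown here, hydrogen in place of benzoyl on an amide-type nitrogen gives a 1.3-fold lower number from compound 1 to compound 3 (0.12 log units; within the scatter), the first direct reading of what this position is worth. Compound 3 keeps its remaining benzoyl and still gives a measured number, so the activity seen for compound 1 in this assay does not require a second benzoyl on this nitrogen. The data shown offer no measured property that explains why this change leaves the read-out within the scatter.

Compound 2 is reported only as a limit, > 3000 nM, so it provides no number against which the remaining benzoyl can be weighed. Still open, from the compounds shown here alone, is whether that benzoyl can give way to a smaller acetyl group, a 4-methoxybenzoyl group or a chain ending in a carboxylic acid, and whether the same hydrogen-for-benzoyl exchange would hold on a core bearing something other than the four chlorines.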